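Aryl replacements at the alkyne carbon of the shared core

The compounds below may be only part of what the source reports. "The series", "measured", "known", "first", "only" and "open" are said of these compounds alone.

Compound 1 `Nc1ncnn2c([C@@H]3O[C@H](CO)[C@@H](O)[C@H]3O)cc(C#CC3CC3)c12` carries a 2-cyclopropylethynyl group on the core and gives 30 nM in a functional assay on LN-229 cells (Homo sapiens) for antiproliferative activity, with a stated time of 72 h; on this read-out lower numbers stand for stronger inhibition and higher numbers for weaker inhibition. Compound 2 `Nc1ncnn2c([C@@H]3O[C@H](CO)[C@@H](O)[C@H]3O)cc(C#Cc3ccc(F)cc3)c12` reaches only the limit > 100000 nM in this assay, so no number is known for it (the limit of > 100000 nM in this assay, at which 1 of the 3 values shown sits). Compound 3 `Nc1ncnn2c([C@@H]3O[C@H](CO)[C@@H](O)[C@H]3O)cc(-c3ccc(Cl)cc3)c12` gives 32600 nM in this assay; this is the highest of the two numbers, with compound 1 the nearest, a 1100-fold higher number from compound 1 to compound 3 (3.04 log units; beyond the scatter). The step of an at least 3300-fold higher number from compound 1 to compound 2 (3.52 log units; beyond the scatter) runs the same way, while an at least 3.0-fold lower number from compound 2 to compound 3 (0.48 log units; beyond the scatter) shows a direct aryl on the ring doing somewhat better than the aryl on the alkyne.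

Compound 4 `Nc1ncnn2c([C@@H]3O[C@H](CO)[C@@H](O)[C@H]3O)cc(-c3ccsc3)c12` differs from compound 3 by thiophen-3-yl in place of 4-chlorophenyl on an aromatic carbon. Both steps into compound 3 concern the same position and exchange one aromatic ring for another substituent, so they bear on this change, though neither concerns a five-membered aromatic ring. A direct aryl at this position has so far given weak inhibition, and a smaller ring moves part of the way toward the small group of compound 1. For compound 4 a modest step, a 3.3-fold lower number from compound 3 to compound 4 (0.51 log units; beyond the scatter), toward a lower number is expected in this assay. Compound 4 is estimated at 10000 nM, within 2000 nM to 50000 nM.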

Compound 4, half-maximal inhibitory concentration: 57700 nM
For compound 4 the middle estimate is 5.8-fold (0.76 log units) below the measured one, outside the stated range (above it).
By their numbers in this assay, from the lowest: compound 1; then compounds 3 and 4 (each within the scatter of the next). At a limit, above all of these: compound 2.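

Notes on the direct ring at this position: in this assay, replacing the six-membered aromatic ring of 4-chlorophenyl with the five-membered thiophen-3-yl gives a 1.8-fold higher number from compound 3 to compound 4 (0.25 log units; within the scatter), so this change of ring size and hetero atom separates nothing, while the distance from the alkyne group stays large, with a 1900-fold higher number from compound 1 to compound 4 (3.28 log units; beyond the scatter). The step of an at least 1.7-fold lower number from compound 2 to compound 4 (0.23 log units; that floor lies within the scatter) gives only a floor, so it sets no order between the thiophen-3-yl on the aromatic carbon and the aryl carried on the alkyne. Compound 2 has a limit of the assay and not a number: the limit of > 100000 nM in this assay, at which 1 of the 4 values shown sits.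

Still open, going by these compounds, is whether the low number of compound 1, 30 nM, needs the triple bond, since a cyclopropyl group set directly on the aromatic carbon would test this, or whether a longer alkyl chain or an amine on the alkyne keeps it. Also open, on these data alone, is whether any direct ring at this position, such as a pyridine or a cyclohexyl ring, departs from the narrow band of compound 3 and compound 4.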